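Adding a second chloro to the pyridine-bearing side chain

The compounds below may be only part of what the source reports. "The series", "measured", "known", "first", "only" and "open" are said of these compounds alone.

Compounds measured so far in an assay on isolated protein for activation of cGMP-dependent protein kinase 1 (Homo sapiens), read by ADP-Glo, with stated times of 30 min and 2 h; on this read-out higher numbers stand for an effect only at larger amounts of compound and lower numbers for an effect already at smaller amounts:
Compound 1, `Cc1cc(C(=O)O)ccc1CN1CCC[C@H](O[C@H](CO)c2cc(Cl)cc(Cl)c2)[C@@H]1c1ccc(F)cc1`: "nd" (no result reported)
Compound 2, `Cc1cc(C(=O)O)ccc1CN1CCC[C@H](OC(c2cc(Cl)cc(Cl)c2)C(C)O)[C@@H]1c1ccccc1`: > 196000 nM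
Compound 3, `Cc1cc(C(=O)O)ccc1CN1CCC[C@H](O[C@H](CO)c2ccnc(Cl)c2)[C@@H]1c1ccccc1`: > 200000 nM

Compound 3 stands only at a limit of this assay, not at a number, and that limit is the limit of > 200000 nM in this assay, at which 1 of the 3 values shown sits. Compound 2 likewise reached only a limit, (the limit of > 196000 nM in this assay, at which 1 of the 3 values shown sits). For compound 1 no result was reported. For the measured compounds named here, the one step among the measured compounds, a step that the two limits leave unreadable from compound 2 to compound 3, is therefore unreadable, since both of its ends are limits.

Compound 4, `Cc1cc(C(=O)O)ccc1CN1CCC[C@H](O[C@H](CO)c2cc(Cl)nc(Cl)c2)[C@@H]1c1ccccc1`, differs from compound 3 by a single change: chloro in place of hydrogen on an aromatic carbon. Taken one bond further out, the side-chain ring goes from 2-chloropyridin-4-yl to 2,6-dichloropyridin-4-yl, with the new chloro next to the ring nitrogen and meta to the existing chloro group.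

Going by the values given here, no measured step bears on this change in a readable way; every value shown is a limit or is absent. On that basis compound 4 is expected to remain at the same limit, with an estimated value of 200000 nM and a range from 50000 nM to 1000000 nM. The expected step is then a number no higher from compound 3 to compound 4 (the limit leaves the size open), which is no change beyond the scatter.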

Compound 4, half-maximal effective concentration: > 200000 nM
Compound 4: only a limit was reported; the forecaster's own chance of this, stated with the estimate: 85%; the middle value sits exactly at the limit.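

In this assay compound 4 gives > 200000 nM, which is a limit and not a number. Compound 2 and compound 3 also stand only at limits, and the steps from each of them to compound 4 cannot be read. The compounds shown leave open what chloro in place of hydrogen on an aromatic carbon does in this assay, where none of them gives a number.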